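Pyrazole attachment change on the biaryl amide series

A few compounds are considered here, and "the series" means these few. Any claim that something is new, unique, unknown or untested is made for them only; others in the source may bear on it.

Measured so far:
- compound 1 `O=C(N[C@H]1CCOC[C@@H]1O)c1cn(Cc2ccc(-n3cccn3)cc2)c2cccnc12`: < 8 mL/min/kg
- compound 2 `O=C(NC[C@@H]1CCCO1)c1cn(Cc2ccc(-n3cccn3)cc2)c2cccnc12`: 133 mL/min/kg
- compound 3 `Cc1cnc2c(C(=O)N[C@H]3CCOC[C@@H]3O)cn(Cc3ccc(-c4ccn(C)n4)cc3)c2c1`: 2.5 mL/min/kg

In an ADME assay on liver for metabolic stability, with Liver microsome (Homo sapiens) as the target, using microsomes (a lower number here means slower removal, a higher number faster removal of the compound), compound 1 gives < 8 mL/min/kg, and this is a limit of the assay rather than a number. Compound 2 differs from compound 1 only at the amide nitrogen, and the step of an at least 16-fold higher number from compound 1 to compound 2 (1.22 log units; beyond the scatter) is large. Compound 3 carries a methyl on the core and a methylated pyrazol-3-yl on the phenyl; in this assay compound 3 gives 2.5 mL/min/kg. For the measured compounds named here, no single-point step links compound 3 to compound 1 or compound 2, so only its value is noted.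

Compound 4 `O=C(N[C@H]1CCOC[C@@H]1O)c1cn(Cc2ccc(-c3cc[nH]n3)cc2)c2cccnc12` is the unmeasured member. Its change from compound 1 is 1H-pyrazol-3-yl in place of 1H-pyrazol-1-yl on an aromatic carbon. Going by the values given here, the only measured step, from compound 1 to compound 2, concerns the amide side and not the aryl pyrazole, so it does not bear directly on this change. The read-outs of compound 1 and compound 3, both carrying the 3-hydroxyoxan-4-yl amide, sit at or near the low end, per (the limit of < 8 mL/min/kg in this assay, at which 1 of the 3 values shown sits). For compound 4 the expected step is therefore a step that the limit leaves unreadable from compound 1 to compound 4, none beyond the scatter. Compound 4 is expected to give about 6 mL/min/kg, in the range 2 mL/min/kg to 16 mL/min/kg.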

Compound 4, clearance: 9.2 mL/min/kg
For compound 4 the middle estimate is 1.5-fold (0.19 log units) below the measured one, and the stated range covers the measured number.
By their numbers in this assay, from the lowest: compound 3; then compound 4; then compound 2.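

In this assay, for the compounds shown here, 1H-pyrazol-3-yl in place of 1H-pyrazol-1-yl on an aromatic carbon, para to a large group, gives an at least 1.1-fold higher number from compound 1 to compound 4 (0.06 log units; that floor lies within the scatter); this is the first read on the pyrazole attachment with the 3-hydroxyoxan-4-yl amide and the core held fixed. The value of compound 1, < 8 mL/min/kg, is a limit of the assay and not a number, so only a floor can be read for this step: the limit of < 8 mL/min/kg in this assay, at which 1 of the 4 values shown sits. The change swaps a group with 0 hydrogen-bond donors for one with 1 hydrogen-bond donor, and in this assay compound 4 gives 9.2 mL/min/kg, so the pair shows no shift beyond the scatter, though a larger true step cannot be excluded.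

As far as these compounds go, the true size of the step stays open, as does whether the same pyrazole change would read alike with the (oxolan-2-yl)methyl amide of compound 2. From the compounds shown here alone, how an amine or a carboxylic acid in place of the pyrazole at this position would read in this assay also stays open.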